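The compounds below may be only part of what the source reports. "The series", "measured", "known", "first", "only" and "open" are said of these compounds alone.

Measured compounds:
- compound 1, `ClCc1ccccc1Cn1cnc2c(Cl)nc(Cl)nc21`: 3310 nM
- compound 2, `ClCc1cccc(Cn2cnc3c(Cl)ncnc32)c1`: 5750 nM
- compound 3, `ClCc1ccc(Cn2cnc3nc(Cl)nc(Cl)c32)cc1`: 5120 nM

All three were tested in a functional assay on SK-MEL-28 cells (Homo sapiens) for cytotoxicity, read by sulforhodamine B assay, with a stated time of 48 h; on this read-out lower numbers stand for stronger inhibition of growth and higher numbers for weaker inhibition of growth. Compound 2 gives the largest of the three numbers, yet its gap to compound 3 and its gap to compound 1 both fall within the usual scatter of this assay, so the three compounds cannot be told apart on these data. Compound 4, `ClCc1cccc(Cn2cnc3c(Cl)nc(Cl)nc32)c1`, has not been measured. It differs from compound 2 in a single place: chloro in place of hydrogen on an aromatic carbon. With this change compound 4 carries the same fused core with two chloro groups that compound 1 and compound 3 already carry, and both of those give numbers close to that of compound 2. Among the measured compounds shown here, since no step between the measured compounds is known, the step from compound 2 to compound 4 is expected to be small, within the scatter, with at most a slight lean toward a lower number, as a 1.3-fold lower number from compound 2 to compound 4 (0.11 log units; within the scatter). For compound 4 the estimated value is therefore 4500 nM, with a likely range from 2000 nM to 10000 nM.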

Compound 4, concentration for total growth inhibition: 5370 nM
Compound 4: the middle estimate sits 1.2-fold (0.08 log units) below what was measured; the measured number falls inside the stated range.
By their numbers in this assay, from the lowest: compounds 1, 3, 4 and 2 (each within the scatter of the next).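

In this assay, among the compounds shown here, chloro in place of hydrogen on an aromatic carbon between two ring nitrogen atoms gives a 1.1-fold lower number from compound 2 to compound 4 (0.03 log units; within the scatter) and offers the first comparison here in which only one place differs. At this position, hydrogen and chloro therefore cannot be told apart in this test of growth inhibition, although a single step on one pair of compounds cannot show whether this holds elsewhere. Nothing available explains this result.

Going by these compounds, only hydrogen and chloro are seen at this position, so it remains open whether an amine, a methoxy group or a longer chain there would give a number clearly apart from those of compound 2 and compound 4. On these data alone, it is also open what a carboxylic acid would do in place of the chloromethyl group that all the compounds share.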